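Heteroaryl swap on the sulfonamide nitrogen: pyrimidine to thiazole

This account rests on a few compounds, and the source may have more. Where it says the series, first, only, none or still open, it means among the compounds named here.

Compound 2 `C=C1CC[C@@H]2[C@](C)(COC(C)=O)[C@H](OC(C)=O)CC[C@@]2(C)[C@H]1CC(Nc1ccc(S(=O)(=O)Nc2ncccn2)cc1)C1=CCOC1=O` is the starting point of this step. In a functional assay on Hs-578T cells (Homo sapiens) for inhibition, read by sulforhodamine B assay, with a stated time of 48 h (on this read-out higher numbers stand for lower toxicity in this test and lower numbers for higher toxicity in this test), compound 2 gives > 100000 nM, which is a limit of the assay and not a number. Compound 1 `C=C1CC[C@@H]2[C@](C)(COC(C)=O)[C@H](OC(C)=O)CC[C@@]2(C)[C@H]1CC(Nc1ccc(S(=O)(=O)Nc2ccc(Cl)nn2)cc1)C1=CCOC1=O` differs from it only in the heteroaryl group on the sulfonamide nitrogen. In this assay compound 1 gives > 100000 nM, again a limit rather than a number. Going by the values given here, the only measured step in the set, a step that the two limits leave unreadable from compound 1 to compound 2, therefore has no readable size, since both values sit at the limit of > 100000 nM in this assay, at which 2 of the 2 values shown sit.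

Compound 3 `C=C1CC[C@@H]2[C@](C)(COC(C)=O)[C@H](OC(C)=O)CC[C@@]2(C)[C@H]1CC(Nc1ccc(S(=O)(=O)Nc2nccs2)cc1)C1=CCOC1=O` is the next member and has not been measured. It differs from compound 2 by 1,3-thiazol-2-yl in place of pyrimidin-2-yl on a sulfonamide nitrogen. The measured step that bears on this change is a step that the two limits leave unreadable from compound 1 to compound 2, and it shows no size at all, so the series gives no basis for a shift in either direction in this assay. Compound 3 is expected to remain at the limit of the assay, with an estimated value of 100000 nM and a range from 40000 nM to 300000 nM. The expected step of a number no higher from compound 2 to compound 3 (the limit leaves the size open) is accordingly one of no change beyond the scatter.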

Compound 3, concentration lethal to 50% of the cells: > 100000 nM
Compound 3: no number, only a limit; the forecaster's own chance of this, stated with the estimate: 80%; the middle value lies on the limit itself.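

No step among compound 1, compound 2 and compound 3 can be read in this assay, as each result is a limit of the assay and not a number: the limit of > 100000 nM in this assay, at which 3 of the 3 values shown sit.

The compounds shown leave open whether exchanging the heteroaryl group on the sulfonamide nitrogen changes the read-out at all.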